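Fluorine shift on the shared core, compound 3 to compound 4

The source may hold more compounds than are shown below. What is called first, only, known or untested is meant among the compounds shown, and "the series" means these compounds.

Three compounds carry a measurement in an assay on microsomes for inhibition of 3-hydroxy-3-methylglutaryl-coenzyme A reductase (Rattus norvegicus); on this read-out higher numbers stand for weaker inhibition and lower numbers for stronger inhibition. Compound 1 `CC(C)=Cc1c(-c2ccccc2)sc(C(C)C)c1/C=C/[C@@H](O)C[C@@H](O)CC(=O)O` gives 1000 nM. Compound 2 `CC(C)c1sc(-c2ccccc2)c(C2CCCCC2)c1/C=C/[C@@H](O)C[C@@H](O)CC(=O)O` gives 202 nM, and compound 3 `CC(C)c1sc(-c2ccccc2)c(-c2ccccc2F)c1/C=C/[C@@H](O)C[C@@H](O)CC(=O)O` gives 233 nM. Compound 3 thus stands second highest of the three numbers; its nearest neighbour is reached by a 1.2-fold higher number from compound 2 to compound 3 (0.06 log units; within the scatter) and its furthest by a 4.3-fold lower number from compound 1 to compound 3 (0.63 log units; beyond the scatter). The remaining step is a 5.0-fold lower number from compound 1 to compound 2 (0.69 log units; beyond the scatter).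

Compound 4 `CC(C)c1sc(-c2ccccc2)c(-c2cccc(F)c2)c1/C=C/[C@@H](O)C[C@@H](O)CC(=O)O` has not been measured in this assay. It differs from compound 3 by 3-fluorophenyl in place of 2-fluorophenyl on an aromatic carbon: the 2-fluorophenyl leaves and the 3-fluorophenyl enters, on an aromatic carbon of the five-membered aromatic ring with one sulfur, next to the ring atom that bears a phenyl group. For the measured compounds named here, no measured step moves a fluorine within the same ring. The nearest guidance is a 1.2-fold higher number from compound 2 to compound 3 (0.06 log units; within the scatter), a step within the scatter, while the two steps from compound 1 were both modest and in the lowering direction. A six-membered aromatic ring carrying one fluorine is kept in compound 4, so no step beyond the scatter is expected in this assay: a 1.1-fold higher number from compound 3 to compound 4 (0.03 log units; within the scatter). Compound 4 is estimated at 250 nM, with a range from 100 nM to 600 nM.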

Compound 4, half-maximal inhibitory concentration: 49 nM
The estimate for compound 4 lay 5.1-fold (0.71 log units) above the measured number; measured number below the stated range.
By their numbers in this assay, from the lowest: compound 4; then compounds 2 and 3 (each within the scatter of the next); then compound 1.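

In this assay, moving the fluorine within its ring, with the same atoms joined differently, gives a 4.8-fold lower number from compound 3 to compound 4 (0.68 log units; beyond the scatter) and is enough to shift the read-out beyond the scatter, so this aromatic carbon of the shared core responds to where the fluorine sits and not only to which kind of group is attached. The earlier compounds shown here did not show this: 2-fluorophenyl and cyclohexyl stayed within the scatter of each other, whereas 3-fluorophenyl separates from cyclohexyl with a 4.1-fold lower number from compound 2 to compound 4 (0.62 log units; beyond the scatter) and so stands apart from both groups. For the compounds shown here, the range of this position also widens, with a 20-fold lower number from compound 1 to compound 4 (1.31 log units; beyond the scatter) as the only large step so far. Nothing measured on these compounds accounts for the effect of the fluorine shift.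

Still open, on these data alone, is whether the lower number belongs to fluorine as such, or would also come with a chlorine, a nitrile or a methoxy group in its place, or with a plain phenyl at this position. Also open, as far as these compounds go, is whether the fluorine shift keeps its size when a cyclopropyl replaces the isopropyl group on the shared core.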